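A few compounds are considered here, and "the series" means these few. Any claim that something is new, unique, unknown or untested is made for them only; others in the source may bear on it.

In a functional assay on BXPC-3 cells (Homo sapiens) for antiproliferative activity, read by MTT assay, with a stated time of 24 h (a lower number here means a stronger inhibitor, a higher number a weaker inhibitor), compound 1 `CCn1c(C(=O)NCCN)ccc1C(CC)(CC)c1ccc(OCS(=O)(=O)c2ccccc2)c(C)c1` gives 6430 nM. Compound 2 `CCn1c(C(=O)N[C@H](CO)CCCO)ccc1C(CC)(CC)c1ccc(OCS(=O)(=O)c2ccccc2)c(C)c1` stands at > 50000 nM, which is a limit of the assay and not a number. Compound 3 `CCn1c(C(=O)N[C@@H](CO)CCCO)ccc1C(CC)(CC)c1ccc(OCS(=O)(=O)c2ccccc2)c(C)c1` differs from compound 2 in configuration alone: the two compounds have the same atoms and bonds and differ only in configuration as drawn: 1 of 1 stereo elements differ; a stereocentre at a saturated chain carbon is drawn S in compound 2 and R in compound 3. For the measured compounds named here, the only measured step, an at least 7.7-fold higher number from compound 1 to compound 2 (0.89 log units; beyond the scatter), exchanges the group on the amide-type nitrogen and leaves configuration untested, so it gives no size for this change. No step beyond the scatter is therefore expected, and compound 3 is likely to stay weak. The estimated step is a number no higher from compound 2 to compound 3 (the limit leaves the size open). Compound 3 is expected at 50000 nM, within an estimated range of 20000 nM to 100000 nM.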

Compound 3, half-maximal inhibitory concentration: 16400 nM
For compound 3 the middle estimate is 3.0-fold (0.48 log units) above the measured one; the measured number lies below the stated range.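

In this assay, going by these compounds, configuration alone at this saturated chain carbon moves the number, with an at least 3.0-fold lower number from compound 2 to compound 3 (0.48 log units; beyond the scatter), and the comparison isolates that change: the fact that compounds 2 and 3 differ only in the configuration as drawn Compound 2 stands at a limit of the assay, not a number, so the full size of this step stays open: the limit of > 50000 nM in this assay, at which 1 of the 3 values shown sits. Even drawn R, the group of 7 heavy atoms on the amide-type nitrogen gives a 2.6-fold higher number from compound 1 to compound 3 (0.41 log units; beyond the scatter).

The compounds shown leave open how a carboxylic acid or a longer amine chain on that nitrogen would stand. They also leave open whether configuration would count there as it does here.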